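A few compounds are considered here, and "the series" means these few. Any claim that something is new, unique, unknown or untested is made for them only; others in the source may bear on it.

The four compounds here share one core, with compound 1 `OC(Cc1ccccc1)CN1CCC(NCCSC(c2ccc(F)cc2)c2ccc(F)cc2)CC1` and compound 2 `[O-][S+](CCNC1CCN(CC(O)Cc2ccccc2)CC1)C(c1ccc(F)cc1)c1ccc(F)cc1` as the two parents. The difference between these two cores is not broken down here. Compound 3 `O=C(c1ccc(F)cc1)N1CCC(NCCSC(c2ccc(F)cc2)c2ccc(F)cc2)CC1` arises from compound 1, and compound 4 `O=C(c1ccc(F)cc1)N1CCC(NCC[S+]([O-])C(c2ccc(F)cc2)c2ccc(F)cc2)CC1` arises from compound 2, each by the same kind of change. From compound 1 to compound 3 the change is (4-fluorophenyl)carbonyl in place of 2-hydroxy-3-phenylpropyl on an amine nitrogen in a ring; from compound 2 to compound 4 it is (4-fluorophenyl)carbonyl in place of 2-hydroxy-3-phenylpropyl on an amine nitrogen in a ring. In an assay on membranes from HEK293 cells for displacement of a labelled ligand from D(4) dopamine receptor (Homo sapiens), read by scintillation counting, with a stated time of 60 min (a higher number here means a weaker inhibitor, a lower number a stronger inhibitor), compound 1 gives 2200 nM, while compound 3 gives 9020 nM; the step of a 4.1-fold higher number from compound 1 to compound 3 (0.61 log units; beyond the scatter) marks a clear loss of binding. For compound 2 the result in this assay is "not determined" (no result reported), so the size of the step from compound 2 to compound 4 cannot be stated; the starting point is missing. For the measured compounds named here, the only anchor for compound 4 is compound 3, which gives 9020 nM in this assay, and the expectation is that compound 4 lands in the same weak range. For compound 4 the value in this assay is estimated at 9000 nM, between 2500 nM and 30000 nM.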

Compound 4, inhibition constant: > 100000 nM
Compound 4: only a limit was reported (the forecaster's own chance of this, stated with the estimate: 15%); middle value at least 11-fold (1.04 log units) away from the limit.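

In this assay compound 4 gives > 100000 nM, which is a limit and not a number. For the compounds shown here, compound 2 has no single number either, so no step from compound 2 to compound 4 can be read. The compounds shown leave open how far (4-fluorophenyl)carbonyl in place of 2-hydroxy-3-phenylpropyl shifts binding on the core of compound 2, and whether that shift matches the one on the core of compound 1.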